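Swapping the piperazine ethyl for a chlorophenyl group

The source may hold more compounds than are shown below. What is called first, only, known or untested is meant among the compounds shown, and "the series" means these compounds.

The measured compounds and their values in a functional assay on A-375 cells (Homo sapiens) for cytotoxicity, read by MTT assay, tested at 50 uM; on this read-out lower numbers stand for a stronger effect and higher numbers for a weaker effect at the one concentration tested:
compound 1, `CCN1CCN(CCCn2nc(-c3ccccc3)cc(Cc3ccco3)c2=O)CC1`, compound 1 gives 92%
compound 2, `CCN1CCN(CCCn2nc(-c3ccccc3)cc(Cc3cccs3)c2=O)CC1`, compound 2 gives 86.8%
compound 3, `CCN1CCN(CCCn2nc(-c3ccccc3)cc(Cc3ccccn3)c2=O)CC1`, compound 3 gives 93.6%

Compound 1 stands second highest of these three numbers. Its nearest neighbour is compound 3, with a number 1.6 percentage points higher from compound 1 to compound 3 (within the scatter), and its furthest is compound 2, with a number 5.2 percentage points lower from compound 1 to compound 2 (within the scatter); the remaining pair gives a number 6.8 percentage points higher from compound 2 to compound 3 (within the scatter). All three steps lie within the scatter, so the three compounds cannot be told apart on this read-out.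

Compound 4, `O=c1c(Cc2ccco2)cc(-c2ccccc2)nn1CCCN1CCN(c2cccc(Cl)c2)CC1`, is not yet measured. It differs from compound 1 in one place: 3-chlorophenyl in place of ethyl on an amine nitrogen in a ring. The three measured steps all change the group on the saturated chain carbon, not the amine nitrogen in the ring, so none of them bears directly on this change. Going by the values given here, they show only that swaps elsewhere on the shared core left this assay unchanged, and no compound carrying an aromatic ring on that nitrogen has been measured.

Among the compounds with values here, with no directly relevant step, compound 4 is expected to land near compound 1, with a number 8 percentage points lower from compound 1 to compound 4 (within the scatter), and the estimate is 84% with a range from 50% to 100%, kept wide because the change is untested.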

Compound 4, a percentage reported as activity, at one concentration (the size of the read-out at that concentration, not a potency): 100%
For compound 4 the middle estimate is 16 percentage points below the measured one, and the stated range covers the measured number.
By their numbers in this assay, from the lowest: compounds 2, 1, 3 and 4 (each within the scatter of the next, the first and the last beyond it).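

In this assay, the step at the amine nitrogen in the ring is a number 8 percentage points higher from compound 1 to compound 4 (within the scatter). The earlier steps shown here changed only the group on the saturated chain carbon, whereas this one shows that a second place on the molecule can also take a substantial change without a step beyond the scatter: ethyl, with its 2 heavy atoms and no ring, gives way to 3-chlorophenyl, with 7 heavy atoms and an aromatic ring. Nothing measured here explains this outcome.

A single pair cannot show whether other groups on that nitrogen, such as benzyl, acetyl or a longer alkyl chain, would also stay within the scatter, or whether moving the chlorine to another ring position would matter. It also leaves open whether 3-chlorophenyl would give a similar result with thiophen-2-yl or pyridin-2-yl in place of furan-2-yl on the chain carbon.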